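The source may hold more compounds than are shown below. What is called first, only, known or untested is meant among the compounds shown, and "the series" means these compounds.

Measured compounds:
Compound 1 `CC(Sc1nnc(-c2ccncc2)s1)C(=O)Nc1ccccc1`, in an ADME assay on HepG2 cells (Homo sapiens) for cytotoxicity, with a stated time of 3 days (on this read-out higher numbers stand for lower toxicity in this test and lower numbers for higher toxicity in this test), compound 1 gives > 50000 nM, which is a limit of the assay.
Compound 2 `O=C(CCSc1nnc(-c2ccncc2)s1)Nc1c(Cl)cccc1Cl`, in this assay compound 2 gives 12600 nM.
Compound 3 `O=C(CCSc1nnc(-c2ccncc2)s1)Nc1ccc(Cl)cc1Cl`, in this assay compound 3 gives > 50000 nM, which is a limit of the assay.

Compound 3 therefore stands at the upper end of the measured set, and only a limit is known for it; the same holds for compound 1, so the measured numbers give little foothold there (the limit of > 50000 nM in this assay, at which 2 of the 3 values shown sit). Going by the values given here, the single counted step, an at least 3.9-fold higher number from compound 2 to compound 3 (0.59 log units; beyond the scatter), shows that moving the chloro groups on the amide-type nitrogen's aryl ring shifted the number beyond the scatter, with the 2,4-dichlorophenyl compound the less toxic of the pair.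

Compound 4 `O=C(CCSc1nnc(-c2ccncc2)s1)Nc1ccccc1Cl` differs from compound 3 by hydrogen in place of chloro on an aromatic carbon, that is, 2,4-dichlorophenyl to 2-chlorophenyl. As far as these compounds go, the step from compound 2 to compound 3 bears on it only loosely, as it changes chloro placement rather than chloro count, and it ends at a limit, so its true size is unknown. With both neighbouring data points at the limit, no step beyond the scatter is expected in this assay in either direction; compound 4 is expected to sit near the limit again, an expected step of an at least 1.2-fold lower number from compound 3 to compound 4 (0.09 log units; that floor lies within the scatter). The estimate for compound 4 is 40000 nM, with a range from 12000 nM to 150000 nM.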

Compound 4, half-maximal cytotoxic concentration: > 50000 nM
Compound 4: no number, only a limit (the forecaster's own chance of this, stated with the estimate: 55%); middle value at least 1.2-fold (0.09 log units) from the limit.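

In this assay compound 4 gives > 50000 nM, again a limit of the assay. Taking the chloro away from the 2,4-dichlorophenyl ring leaves the read-out at the limit, and the step between compound 3 and compound 4 cannot be read, as both ends are limits; the 2-chlorophenyl ring with its single chloro nevertheless keeps the distance to the 2,6-dichlorophenyl compound, an at least 3.9-fold higher number from compound 2 to compound 4 (0.59 log units; beyond the scatter). Compound 2 thus remains the only compound with a number rather than a limit, so the one measurable signal of toxicity in this small set belongs to the 2,6-dichlorophenyl ring alone, and the rest of the set gives no gradation: the limit of > 50000 nM in this assay, at which 3 of the 4 values shown sit.

As far as these compounds go, how far compound 1, compound 3 and compound 4 lie past the limit stays unknown, so no order among them can be given. Also open, from the compounds shown here alone, is whether the number drops again with a second group other than chloro on the same ring, such as methyl, methoxy or trifluoromethyl, or with a carboxylic acid on that ring or a longer chain on the sulfur.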